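Pyrazin-2-yl for benzyl on the ring nitrogen

A few compounds are considered here, and "the series" means these few. Any claim that something is new, unique, unknown or untested is made for them only; others in the source may bear on it.

Measured compounds:
compound 1 `Nc1ccccc1NC(=O)c1ccc(CSC(=S)N2CCN(C3CCCCC3)CC2)cc1`: 30.6%
compound 2 `Nc1ccccc1NC(=O)c1ccc(CSC(=S)N2CCN(Cc3ccccc3)CC2)cc1`: 20.6%

In a functional assay on HeLa cells (Homo sapiens) for antiproliferative activity, read by CCK-8 assay, with a stated time of 72 h, tested at 2 uM (on this read-out higher numbers stand for a stronger effect at the one concentration tested and lower numbers for a weaker effect), compound 1 gives 30.6% and compound 2 gives 20.6%. Compound 2 carries the smaller of the two numbers, but the step of a number 10 percentage points lower from compound 1 to compound 2 (within the scatter) lies within the scatter, so the two compounds are not told apart on this read-out.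

Compound 3 `Nc1ccccc1NC(=O)c1ccc(CSC(=S)N2CCN(c3cnccn3)CC2)cc1` differs from compound 2 in one place: pyrazin-2-yl in place of benzyl on an amine nitrogen in a ring. Among the measured compounds shown here, the only measured step touches the same ring nitrogen, a number 10 percentage points lower from compound 1 to compound 2 (within the scatter), and it stays within the scatter. For the measured compounds named here, no measured step exchanges an aromatic ring of carbon only for one with two nitrogen atoms, so the data give no ground for a change beyond the scatter in this assay. The step from compound 2 to compound 3 is therefore expected to be small, a number 1.4 percentage points higher from compound 2 to compound 3 (within the scatter). Compound 3 is estimated at 22%, with a range from 8% to 40%.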

Compound 3, a percentage reported as inhibition, at one concentration (the size of the read-out at that concentration, not a potency): 70.4%
The estimate for compound 3 lay 48.4 percentage points below the measured number; measured number above the stated range.
By their numbers in this assay, from the lowest: compounds 2 and 1 (each within the scatter of the next); then compound 3.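

In this assay the ring nitrogen turns out to be a position that can shift the read-out strongly: there is a number 49.8 percentage points higher from compound 2 to compound 3 (beyond the scatter) and also a number 39.8 percentage points higher from compound 1 to compound 3 (beyond the scatter), whereas the exchange of cyclohexyl for benzyl at the same place stayed within the scatter. Among the compounds shown here, both large steps end at pyrazin-2-yl, the only one of the three groups with hetero atoms in its ring, so the kind of ring on this nitrogen matters here, and an aromatic ring alone does not bring the gain, as benzyl shows. Nothing available accounts for the size of this step.

The compounds shown leave open whether both ring nitrogen atoms of pyrazin-2-yl are needed, which a pyridin-2-yl or phenyl group on the same nitrogen would test. They also leave open whether the gain at this single concentration would carry over to a measured potency.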